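From 3,4-dimethoxyphenyl to naphthalen-1-yl: an expected growth-inhibition step

A few compounds are considered here, and "the series" means these few. Any claim that something is new, unique, unknown or untested is made for them only; others in the source may bear on it.

In a functional assay on COLO 205 cells (Homo sapiens) for inhibition, read by sulforhodamine B assay, with a stated time of 48 h, tested at 50 uM (a lower number here means less inhibition of growth, a higher number more inhibition of growth at the concentration tested), compound 1 (`COc1ccc(/C=C/C(=O)/C=C/c2ccc(OCc3cn(CCCCOc4cc(=O)oc5ccccc45)nn3)c(OC)c2)cc1OC`) gives 53%. That lies within the scatter of compound 3 (`COc1ccccc1/C=C/C(=O)/C=C/c1ccc(OCc2cn(CCCOc3cc(=O)oc4ccccc34)nn2)c(OC)c1`), which gives 57%. Compound 2 (`COc1cc(/C=C/C(=O)/C=C/c2cccc3ccccc23)ccc1OCc1cn(CCCCCOc2cc(=O)oc3ccccc23)nn1`), at 40%, falls beyond the scatter below compound 1.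

Compound 4 (`COc1cc(/C=C/C(=O)/C=C/c2cccc3ccccc23)ccc1OCc1cn(CCCCOc2cc(=O)oc3ccccc23)nn1`) differs from compound 1 in one place: naphthalen-1-yl in place of 3,4-dimethoxyphenyl on a double-bonded chain carbon bound to a double-bonded chain carbon. Naphthalen-1-yl stands in place of 3,4-dimethoxyphenyl on a double-bonded chain carbon bound to a double-bonded chain carbon. Within the data shown here, no measured step isolates this change. Compound 2 also carries naphthalen-1-yl and gives 40%, so a modest downward step in this assay is expected, perhaps none beyond the scatter. The expected change is a number 7 percentage points lower from compound 1 to compound 4 (within the scatter). For compound 4 the estimated value is 46%, within a range of 33% to 58%.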

Compound 4, percent growth inhibition at one concentration: 50%
The estimate for compound 4 lay 4 percentage points below the measured number, within the range that was stated.
By their numbers in this assay, from the lowest: compounds 2, 4, 1 and 3 (each within the scatter of the next, the first and the last beyond it).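

In this assay, among these compounds, naphthalen-1-yl in place of 3,4-dimethoxyphenyl gives a number 3 percentage points lower from compound 1 to compound 4 (within the scatter), the first step that isolates this change. On a double-bonded chain carbon bound to a double-bonded chain carbon, then, the two hydrogen-bond acceptors of 3,4-dimethoxyphenyl can leave and a second aromatic ring can enter without a step beyond the scatter. No evidence at hand bears on this result.

The compounds shown leave open what a phenyl ring carrying an amine or a carboxylic acid would give at this place. They also leave open whether the same change would read alike with a longer chain on the other side of the molecule.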